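From Methoxy to Methyl on a Phenyl Ring

The compounds below may be only part of what the source reports. "The series", "measured", "known", "first", "only" and "open" are said of these compounds alone.

In a functional assay on LoVo cells (Homo sapiens) for inhibition, read by MTT assay, with a stated time of 24 h (on this read-out higher numbers stand for weaker inhibition and lower numbers for stronger inhibition), compound 2 `COc1cccc(-n2cc(CN3C(=O)C[C@@H]4CC[C@@]3(C)C4(C)C)nn2)c1` gives 80 nM, a value that cannot be told apart from that of compound 1 `COc1ccccc1-n1cc(CN2C(=O)C[C@@H]3CC[C@@]2(C)C3(C)C)nn1` at 70 nM. Among the measured compounds shown here, the only measured step, a 1.1-fold higher number from compound 1 to compound 2 (0.06 log units; within the scatter), exchanges 2-methoxyphenyl for 3-methoxyphenyl. Compound 3 `Cc1cccc(-n2cc(CN3C(=O)C[C@@H]4CC[C@@]3(C)C4(C)C)nn2)c1` instead has methyl in place of methoxy on an aromatic carbon. For the measured compounds named here, no measured step covers this exchange directly, so the small step from compound 1 is only a weak guide, and no change beyond the scatter is expected in this assay. The expected step is no change at the digits printed from compound 2 to compound 3 (within the scatter). Compound 3 is estimated at 80 nM, with an expected range of 35 nM to 180 nM.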

Compound 3, half-maximal inhibitory concentration: 50 nM
The estimate for compound 3 lay 1.6-fold (0.20 log units) above the measured number, within the range that was stated.
By their numbers in this assay, from the lowest: compounds 3, 1 and 2 (each within the scatter of the next).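

In this assay, methyl can take the place of methoxy at this position with no change beyond the scatter (a 1.6-fold lower number from compound 2 to compound 3 (0.20 log units; within the scatter)), so here the loss of the oxygen and its hydrogen-bond acceptor does not register. The comparison with the 2-methoxyphenyl compound agrees (a 1.4-fold lower number from compound 1 to compound 3 (0.15 log units; within the scatter)), leaving all three compounds indistinguishable on this read-out. No measurement here offers an explanation for this result.

Going by these compounds, whether an amine, a carboxylic acid or a longer chain at this place on the phenyl ring would also stay within the scatter remains open.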